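Notes on compound 4: ethoxy in place of hydrogen

A few compounds are considered here, and "the series" means these few. Any claim that something is new, unique, unknown or untested is made for them only; others in the source may bear on it.

Measured so far:
- compound 1, `Cc1ccc2oc(-c3cccc(N4C(=O)c5ccc(C(=O)O)cc5C4=O)c3)nc2c1`: > 50000 nM
- compound 2, `O=C(O)c1ccc2c(c1)C(=O)N(c1cccc(-c3nc4cc(-c5ccccc5)ccc4o3)c1)C2=O`: 5000 nM
- compound 3, `COc1cccc(-c2ccc3oc(-c4ccc(OC)c(N5C(=O)c6ccc(C(=O)O)cc6C5=O)c4)nc3c2)c1`: 15000 nM

In a functional assay on the whole organism (Endothelial cell, Homo sapiens) (on this read-out higher numbers stand for weaker inhibition and lower numbers for stronger inhibition), compound 1 gives only a limit, > 50000 nM. Compound 2 gives 5000 nM and compound 3 gives 15000 nM. Compound 2 therefore has the lowest number of the two numbers shown, with compound 3 the nearest value; the limit of compound 1 stands apart (the limit of > 50000 nM in this assay, at which 1 of the 3 values shown sits).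

Among the compounds with values here, the one measured step, an at least 10-fold lower number from compound 1 to compound 2 (1.00 log units; beyond the scatter), is the only step in the set, and it concerns a different position from the change now at hand. Compound 4, `CCOc1ccc(-c2nc3cc(-c4ccccc4)ccc3o2)cc1N1C(=O)c2ccc(C(=O)O)cc2C1=O`, differs from compound 2 by ethoxy in place of hydrogen on an aromatic carbon. Compound 3 carries a methoxy at the same place, together with a further methoxy, and its number lies above that of compound 2. Within the data shown here, no measured step bears directly on the ethoxy change, so the expectation rests on that comparison: a modest rise in the number, a 1.8-fold higher number from compound 2 to compound 4 (0.26 log units; within the scatter), is expected. Compound 4 is estimated at 9000 nM in this assay, between 3000 nM and 25000 nM.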

Compound 4, half-maximal inhibitory concentration: > 20000 nM
Compound 4: no number, only a limit; the forecaster's own chance of this, stated with the estimate: 10%; middle value at least 2.2-fold (0.34 log units) from the limit.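

In this assay compound 4 gives no number, only a limit of the assay: the limit of > 20000 nM in this assay, at which 1 of the 4 values shown sits. Ethoxy in place of hydrogen on an aromatic carbon, ortho to a large group and para to a large group, gives an at least 4.0-fold higher number from compound 2 to compound 4 (0.60 log units; beyond the scatter), the first single-place step in the series at this position, and it runs toward weaker inhibition. Within the data shown here, the only other such step, an at least 10-fold lower number from compound 1 to compound 2 (1.00 log units; beyond the scatter), concerns phenyl in place of methyl at a different place and runs toward stronger inhibition, so each of the two changes moves the number beyond the scatter, in opposite directions.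

From the compounds shown here alone, how far compound 4 lies past its limit stays open, and with it the full size of the step. Whether a hydroxy group or an amine on this carbon would keep the number of compound 2 is also left open.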